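The compounds below may be only part of what the source reports. "The series", "measured", "known", "first", "only" and "open" are said of these compounds alone.

Compound 3 `O=C(Nc1ccc(-c2nc(N3CC4CCC(C3)O4)c3sccc3n2)cc1)NC1CC1` gives the lowest number of the three in a functional assay on LNCaP cells (Homo sapiens) for cytotoxicity (a higher number here means a weaker inhibitor, a lower number a stronger inhibitor), at 40 nM. Compound 1 `CC(=O)Nc1ccc(-c2nc(N3CC4CCC(C3)O4)c3sccc3n2)cc1` gives 1700 nM, and compound 2 `CNC(=O)Nc1ccc(-c2nc(N3CC4CCC(C3)O4)c3sc(CN4CCN(S(C)(=O)=O)CC4)cc3n2)cc1` gives 120 nM in this assay . The step from compound 3 to compound 4 `CS(=O)(=O)N1CCN(Cc2cc3nc(-c4ccc(NC(=O)NC5CC5)cc4)nc(N4CC5CCC(C4)O5)c3s2)CC1` is (4-(methylsulfonyl)piperazin-1-yl)methyl in place of hydrogen on an aromatic carbon. Within the data shown here, the only single-point step recorded, a 43-fold lower number from compound 1 to compound 3 (1.63 log units; beyond the scatter), concerns the carbonyl substituent and does not bear on this change. Compound 2 carries the same entering group but a different urea, so its value and that of compound 3 show only that both sit well below compound 1. Among the measured compounds shown here, with no step directly on this change, compound 4 is expected to stay near compound 3, with a 1.1-fold higher number from compound 3 to compound 4 (0.05 log units; within the scatter) not beyond the scatter, estimated at 45 nM within 15 nM to 130 nM.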

Compound 4, half-maximal inhibitory concentration: 32 nM
For compound 4 the middle estimate is 1.4-fold (0.15 log units) above the measured one; low and high end bracket the measured number.
By their numbers in this assay, from the lowest: compounds 4 and 3 (each within the scatter of the next); then compound 2; then compound 1.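

In this assay, (4-(methylsulfonyl)piperazin-1-yl)methyl can stand on the aromatic carbon next to the ring sulfur with no shift beyond the scatter, as a 1.3-fold lower number from compound 3 to compound 4 (0.10 log units; within the scatter) shows. With that group in place, the carbonyl side still counts: cyclopropyl in place of methyl on the amide-type nitrogen gives a 3.8-fold lower number from compound 2 to compound 4 (0.57 log units; beyond the scatter). Nothing measured here accounts for either step. Going by these compounds, whether a carboxylic acid or a piperazine without the methylsulfonyl would fit this carbon equally well stays open. So does whether the entering group is as neutral alongside the methyl urea.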